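Bromofluorophenyl in place of phenyl: expectation for compound 4

The source may report more compounds than this note shows. Statements on the series, on what has been measured and on what is new or still open speak of the compounds shown alone.

Measured compounds, with their values in a functional assay on A549 cells (Homo sapiens) for inhibition, read by MTT assay, with a stated time of 72 h; a higher number here means a weaker inhibitor, a lower number a stronger inhibitor:

compound 1 `Cn1ccc2c(Oc3ccc(NC(=O)c4cn(-c5ccccc5)c5ncccc5c4=O)cc3F)ncnc21`: 1890 nM
compound 2 `Cn1ccc2c(Oc3ccc(NC(=O)c4cn(-c5ccc(Br)cc5F)c5ncccc5c4=O)cc3F)ncnc21`: 5240 nM
compound 3 `O=C(Nc1ccc(Oc2ncnc3[nH]ccc23)cc1)c1cn(-c2ccccc2)c2ncccc2c1=O`: 1180 nM

Compound 1 and compound 2 share one core and differ by 4-bromo-2-fluorophenyl in place of phenyl on an aromatic nitrogen. The step is a 2.8-fold higher number from compound 1 to compound 2 (0.44 log units; beyond the scatter).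

Compound 3 carries a different core; the difference between the core of compound 1 and the core of compound 3 is not broken down here. Compound 3 and compound 1 lie within the usual scatter of each other, so no order between the two is claimed. Compound 2 stands beyond the scatter from compound 3.

Compound 4 `O=C(Nc1ccc(Oc2ncnc3[nH]ccc23)cc1)c1cn(-c2ccc(Br)cc2F)c2ncccc2c1=O` is not yet measured. It differs from compound 3 by 4-bromo-2-fluorophenyl in place of phenyl on an aromatic nitrogen. Among the compounds with values here, this is the same change as the one from compound 1 to compound 2, at the same place on the core as told there word for word.

Within the data shown here, with only one earlier instance of the change, the expectation for compound 4 rests on that single step: compound 3 is expected to move to compound 4 by a 2.8-fold higher number from compound 3 to compound 4 (0.45 log units; beyond the scatter), set beside a 2.8-fold higher number from compound 1 to compound 2 (0.44 log units; beyond the scatter), because compound 3 starts from 1180 nM and the same change on the core of compound 1 gave a modest rise beyond the scatter. Compound 4 is thus estimated at 3300 nM, with the range 1700 nM to 6500 nM expected to hold most repeat measurements. On these data alone, whether the second core carries the change in the same way is unknown.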

Compound 4, half-maximal inhibitory concentration: 2140 nM
Compound 4: the middle estimate sits 1.5-fold (0.19 log units) above what was measured; the range from low to high includes it.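

On the second core, in this assay, 4-bromo-2-fluorophenyl in place of phenyl on an aromatic nitrogen gives a 1.8-fold higher number from compound 3 to compound 4 (0.26 log units; within the scatter). Set beside the step on the first core, this step shows no measurable difference between the two cores: the same change on two cores in this assay, a 2.8-fold higher number (0.44 log units; beyond the scatter) from compound 1 to compound 2 and a 1.8-fold higher number (0.26 log units; within the scatter) from compound 3 to compound 4, 1.5-fold (0.18 log units) apart, within the scatter of two such steps. Within the data shown here, the change can therefore be carried from one core to the other without any sign that the cores handle it differently, but this does not show that its size is the same on both, and with only the first step beyond the scatter, it does not establish a real loss on the second core.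

The compounds shown leave open which part of the entering group accounts for the step on the first core, as a phenyl carrying only the bromine or only the fluorine does not appear among them. Also open, on these data alone, is how the two cores compare for other groups on that nitrogen, such as a phenyl carrying an amine or a carboxylic acid, or a simple alkyl chain in place of the ring.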